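Isopropyl on the amidine nitrogen across two benzofuran-linked cores

The compounds below may be only part of what the source reports. "The series", "measured", "known", "first", "only" and "open" are said of these compounds alone.

Compound 1 `N=C(N)c1ccc2oc(-c3cccc(OCCCCOc4ccccc4)c3)cc2c1` and compound 3 `N=C(N)c1ccc2cc(-c3cccc(OCCCCCCOc4ccccc4)c3)oc2c1` are the two parent amidines; the difference between their cores is not broken down here. In an ADME assay on L6 cells (Rattus norvegicus) for cytotoxicity, read by resazurin assay, with a stated time of 70 h (on this read-out higher numbers stand for weaker inhibition and lower numbers for stronger inhibition), compound 1 gives 8100 nM, and compound 3 gives 4300 nM, the two lying within the scatter of each other. Compound 2 `CC(C)NC(=N)c1ccc2oc(-c3cccc(OCCCCOc4ccccc4)c3)cc2c1` carries isopropyl in place of hydrogen on an amine nitrogen on the core of compound 1; in this assay compound 2 gives 36500 nM, so that a 4.5-fold higher number from compound 1 to compound 2 (0.65 log units; beyond the scatter). Compound 4 `CC(C)NC(=N)c1ccc2cc(-c3cccc(OCCCCCCOc4ccccc4)c3)oc2c1` carries the same change, (isopropyl in place of hydrogen on an amine nitrogen), on the core of compound 3, the place being the same in both pairs. Within the data shown here, because the only measured instance of this change is a 4.5-fold higher number from compound 1 to compound 2 (0.65 log units; beyond the scatter), a step of similar size is expected from compound 3 to compound 4, namely a 4.4-fold higher number from compound 3 to compound 4 (0.65 log units; beyond the scatter). Compound 4 is thus estimated at 19000 nM in this assay, with a range of 8000 nM to 45000 nM.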

Compound 4, half-maximal inhibitory concentration: 10100 nM
Estimate against measurement, compound 4: 1.9-fold (0.27 log units) above; the range from low to high includes it.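

In this assay, isopropyl in place of hydrogen on the amine nitrogen moves the number in the same direction on the second core, with a 2.3-fold higher number from compound 3 to compound 4 (0.37 log units; beyond the scatter). The two steps agree in direction, and their sizes do not differ beyond the scatter: the same change on two cores in this assay, a 4.5-fold higher number (0.65 log units; beyond the scatter) from compound 1 to compound 2 and a 2.3-fold higher number (0.37 log units; beyond the scatter) from compound 3 to compound 4, 1.9-fold (0.28 log units) apart, within the scatter of two such steps. On these two cores the change therefore carries over within this assay, but two pairs show nothing about other cores or other assays.

The compounds shown leave open whether another group on that nitrogen, such as methyl or benzyl, would give a step of similar size. They also leave open how a butyl or hexyl linker on a single core would bear on the size of the step.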